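This account rests on a few compounds, and the source may have more. Where it says the series, first, only, none or still open, it means among the compounds named here.

Measured compounds:
compound 1, `Cc1nn(-c2nc(-c3ccc(Cl)c(Cl)c3)c(SC(C)C)s2)c(C(=O)O)c1Cc1ccccc1[N+](=O)[O-]`: 20000 nM
compound 2, `Cc1nn(-c2nc(-c3ccc(Cl)c(Cl)c3)c(SC(C)C)s2)c(C(=O)O)c1-c1cccc(Cl)c1C`: 5100 nM
compound 3, `COc1cc(C#N)cc(-c2c(C)nn(-c3nc(-c4ccc(Cl)c(Cl)c4)c(SC(C)C)s3)c2C(=O)O)c1`: 5200 nM

In a functional assay on BJAB cells (Homo sapiens) for antiproliferative activity, with a stated time of 4 days (a lower number here means that less compound is needed, a higher number that more compound is needed for the effect), compound 1 gives the highest of the three numbers. Compound 2 stands closer to compound 1 than compound 3 does, and the two lie within the scatter of each other, as a 1.0-fold higher number from compound 2 to compound 3 (0.01 log units; within the scatter) shows. The unmeasured compound 4, `Cc1nn(-c2nc(-c3ccc(Cl)c(Cl)c3)c(SC(C)C)s2)c(C(=O)O)c1-c1cccc(C(F)(F)F)c1`, is reached from compound 1 by one change: 3-(trifluoromethyl)phenyl in place of 2-nitrobenzyl on an aromatic carbon. Going by the values given here, two measured steps bear on this move, since both replace the same 2-nitrobenzyl on the same aromatic carbon with a six-membered aromatic ring of carbon only: a 3.9-fold lower number from compound 1 to compound 2 (0.59 log units; beyond the scatter) and a 3.8-fold lower number from compound 1 to compound 3 (0.59 log units; beyond the scatter). Both steps are of nearly the same size and in the same direction, and the two substituted rings that enter differ from each other without any difference beyond the scatter in their numbers. A step of similar size, to a lower number, is therefore expected for compound 4, namely a 4.0-fold lower number from compound 1 to compound 4 (0.60 log units; beyond the scatter). Compound 4 is accordingly estimated at 5000 nM, with a range from 2000 nM to 13000 nM, leaving room for the new ring to fall somewhat off the two examples seen so far.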

Compound 4, half-maximal effective concentration: 22000 nM
Compound 4: middle estimate off by 4.4-fold (0.64 log units), on the low side; the whole stated range lies below it.
By their numbers in this assay, from the lowest: compounds 2 and 3 (each within the scatter of the next); then compounds 1 and 4 (each within the scatter of the next).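

In this assay, the 3-(trifluoromethyl)phenyl group on this aromatic carbon cannot be told apart from the 2-nitrobenzyl group it replaces (with a 1.1-fold higher number from compound 1 to compound 4 (0.04 log units; within the scatter)), so swapping the benzyl group for a ring attached directly to the carbon does not by itself lower the number. Among the three rings attached directly at this place, the substituents clearly count: there is a 4.2-fold higher number from compound 3 to compound 4 (0.63 log units; beyond the scatter), and likewise a 4.3-fold higher number from compound 2 to compound 4 (0.63 log units; beyond the scatter), whereas the earlier compounds had shown two quite different rings giving the same result. Nothing shown here offers an explanation for this dependence on the ring's substituents.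

The two rings with the lower numbers, 3-chloro-2-methylphenyl and 3-cyano-5-methoxyphenyl, each carry two substituents, while 3-(trifluoromethyl)phenyl carries one, so the compounds leave open whether the second substituent or the trifluoromethyl group itself separates them. From the compounds shown here alone, a plain phenyl, a 3-chlorophenyl or a 3-cyanophenyl at this place would bear on that question, and how a ring carrying an amine or a carboxylic acid would behave also remains open.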